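Swapping nitro for chloro on a weakly cytotoxic hydrazone

A few compounds are considered here, and "the series" means these few. Any claim that something is new, unique, unknown or untested is made for them only; others in the source may bear on it.

Measured compounds:
Compound 1, `CC(C)c1ccc(/C=N/NC(=O)CSc2nnnn2C)cc1`, 1200000 nM
Compound 2, `Cn1nnnc1SCC(=O)N/N=C/c1ccc(O)cc1`, 632000 nM
Compound 3, `Cn1nnnc1SCC(=O)N/N=C/c1cccc([N+](=O)[O-])c1`, 2000000 nM

All three compounds share one core and were tested in an ADME assay on NIH3T3 cells (Mus musculus) for cytotoxicity, read by XTT assay, with a stated time of 24 h; a lower number here means a stronger inhibitor, a higher number a weaker inhibitor. Compound 3 gives the highest number of the three; compound 1 is nearest to it, and the gap between them is within the scatter, while compound 2 is furthest, and that gap lies beyond the scatter. Within the data shown here, the only step between two measured compounds that differ in one place, a 1.9-fold lower number from compound 1 to compound 2 (0.28 log units; within the scatter), concerns an exchange of hydroxy for isopropyl on an aromatic carbon.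

Compound 4, `Cn1nnnc1SCC(=O)N/N=C/c1cccc(Cl)c1`, has not been measured yet. It differs from compound 3 by chloro in place of nitro on an aromatic carbon. Among the measured compounds shown here, no measured step touches a change of this kind, so the one step available does not bear on it directly; it only shows that a single change on that ring moved the number by an amount within the scatter. For compound 4 a step of about a 1.3-fold lower number from compound 3 to compound 4 (0.10 log units; within the scatter) in this assay is therefore expected, that is, nothing beyond the scatter. The value for compound 4 is estimated at 1600000 nM, with a range from 600000 nM to 4000000 nM.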

Compound 4, half-maximal inhibitory concentration: 7500000 nM
The estimate for compound 4 lay 4.7-fold (0.67 log units) below the measured number; measured number above the stated range.
By their numbers in this assay, from the lowest: compounds 2, 1 and 3 (each within the scatter of the next, the first and the last beyond it); then compound 4.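

In this assay, chloro in place of nitro on an aromatic carbon, meta to a large group, gives a 3.8-fold higher number from compound 3 to compound 4 (0.57 log units; beyond the scatter), so compound 4 is the weaker inhibitor of this pair, though the step is modest. Among these compounds, this is the first exchange of a single group that clearly exceeds the scatter, whereas the one earlier step, a 1.9-fold lower number from compound 1 to compound 2 (0.28 log units; within the scatter), stayed within it and involved different groups, so a change on this ring can measurably alter the reading in this assay. No measurement here explains why the number rose when chloro replaced nitro, and the size of the step is all that can be stated.

On these data alone, it remains open how other groups at this same place would compare, such as an amine, a carboxylic acid or a methoxy group, and so whether chloro stands out or nitro does. Also open, as far as these compounds go, is whether the same exchange of nitro for chloro would give a step of similar size and direction if another part of the shared core carried a longer chain.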